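Furan-2-carbonyl for trifluoromethyl on the shared core

The compounds below may be only part of what the source reports. "The series", "measured", "known", "first", "only" and "open" are said of these compounds alone.

Among the measured compounds shown here, compound 1 `CCOC(=O)c1cnc(C(F)(F)F)nc1NN1C(=O)C=C(C)C1=O` gives 1000 nM in a functional assay on Jurkat cells for inhibition of nuclear factor NF-kappa-B complex (Homo sapiens) (on this read-out lower numbers stand for stronger inhibition and higher numbers for weaker inhibition), the highest of the two numbers measured so far; compound 2 `CCOC(=O)c1cnc(-c2ccsc2)nc1NN1C(=O)C=C(C)C1=O` gives 100 nM. For the measured compounds named here, the one measured step, a 10-fold lower number from compound 1 to compound 2 (1.00 log units; beyond the scatter), is the only one that bears on the change to compound 3 `CCOC(=O)c1cnc(C(=O)c2ccco2)nc1NN1C(=O)C=C(C)C1=O`, namely ((furan-2-yl)carbonyl in place of trifluoromethyl on an aromatic carbon). The entering group again carries a five-membered aromatic ring, so a step in the same direction is expected, though smaller because a 10-fold lower number from compound 1 to compound 2 (1.00 log units; beyond the scatter) concerned a ring attached directly. The expected step is a 3.3-fold lower number from compound 1 to compound 3 (0.52 log units; beyond the scatter). Compound 3 is estimated at 300 nM, range 100 nM to 1000 nM.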

Compound 3, half-maximal inhibitory concentration: 700 nM
Compound 3: middle estimate off by 2.3-fold (0.37 log units), on the low side, within the range that was stated.
By their numbers in this assay, from the lowest: compound 2; then compounds 3 and 1 (each within the scatter of the next).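

In this assay, a 1.4-fold lower number from compound 1 to compound 3 (0.15 log units; within the scatter) leaves (furan-2-yl)carbonyl and trifluoromethyl indistinguishable at this position, whereas a 7.0-fold higher number from compound 2 to compound 3 (0.85 log units; beyond the scatter) sets (furan-2-yl)carbonyl clearly apart from thiophen-3-yl. A five-membered aromatic ring in the entering group therefore does not by itself reproduce the result of compound 2. No evidence on hand accounts for this difference.

The compounds shown leave open whether the carbonyl or the change of ring separates compound 3 from compound 2. As far as these compounds go, how a directly attached furan-2-yl ring, an amine or a carboxylic acid would read out at this position also remains open.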